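From pyridin-4-yl to pyridin-3-yl: one more isomer to test

A few compounds are considered here, and "the series" means these few. Any claim that something is new, unique, unknown or untested is made for them only; others in the source may bear on it.

Going by the values given here, in a functional assay on RKO cells (Homo sapiens) for inhibition, read by CCK-8 assay, with a stated time of 4 days (on this read-out higher numbers stand for weaker inhibition and lower numbers for stronger inhibition), compound 1 `COc1cc(C(=O)O)ccc1NC(=O)[C@@H]1N[C@@H](CC(C)(C)C)[C@](CNCc2ccncc2)(c2ccc(Cl)cc2F)[C@H]1c1cccc(Cl)c1F` gives 200 nM, the lower of the two numbers measured so far and so the stronger inhibition. Among the compounds with values here, the only measured comparison is compound 2 `COc1cc(C(=O)O)ccc1NC(=O)[C@@H]1N[C@@H](CC(C)(C)C)[C@](CNCc2ccccn2)(c2ccc(Cl)cc2F)[C@H]1c1cccc(Cl)c1F`, which gives 720 nM.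

Compound 3 `COc1cc(C(=O)O)ccc1NC(=O)[C@@H]1N[C@@H](CC(C)(C)C)[C@](CNCc2cccnc2)(c2ccc(Cl)cc2F)[C@H]1c1cccc(Cl)c1F` has not yet been measured. It differs from compound 1 in one place only: pyridin-3-yl in place of pyridin-4-yl on a saturated chain carbon bound to an amine nitrogen. It carries pyridin-3-yl in place of pyridin-4-yl on a saturated chain carbon bound to an amine nitrogen, so the two compounds have the same atoms, joined differently.

Within the data shown here, one measured step bears on this change. Pyridin-2-yl in place of pyridin-4-yl at that same place gave a 3.6-fold higher number from compound 1 to compound 2 (0.56 log units; beyond the scatter), modest in size yet beyond the scatter. With that single step as the guide, a change in the same direction but of smaller size is expected in this assay, though one step is thin evidence and the range must stay wide.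

Compound 3 is estimated to give 340 nM, with an expected range of 130 nM to 900 nM. That estimate means an expected 1.7-fold higher number from compound 1 to compound 3 (0.23 log units; within the scatter).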

Compound 3, half-maximal inhibitory concentration: 910 nM
Estimate against measurement, compound 3: 2.7-fold (0.43 log units) below; the measured number lies above the stated range.
By their numbers in this assay, from the lowest: compound 1; then compounds 2 and 3 (each within the scatter of the next).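

In this assay, pyridin-3-yl in place of pyridin-4-yl gives a 4.6-fold higher number from compound 1 to compound 3 (0.66 log units; beyond the scatter), which shows that this position tells the two isomers clearly apart even though they have the same atoms, joined differently. Pyridin-3-yl and pyridin-2-yl, by contrast, give a 1.3-fold higher number from compound 2 to compound 3 (0.10 log units; within the scatter), so those two cannot be separated, and among these three compounds only compound 1, with pyridin-4-yl, stands out as the strongest inhibitor, its steps to both others lying beyond the scatter. Nothing available explains why the place of the ring nitrogen matters here.

The compounds shown all carry a pyridine ring on the same short link to the amine, so it stays open whether a plain phenyl ring, a pyridin-4-yl ring bearing a methyl or methoxy group, or a longer chain between the amine and the ring would match or surpass compound 1 at this place. On these data alone, it also stays open whether the same order of the three isomers would hold in cells other than this one line.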